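Swapping Nitro for Benzyloxy: an Expected Loss of Potency

This account rests on a few compounds, and the source may have more. Where it says the series, first, only, none or still open, it means among the compounds named here.

Compound 1 `COc1ccc(-c2sc(C(=O)O)cc2-c2cc(OC)c(OC)c(OC)c2)cc1[N+](=O)[O-]` and compound 2 `COc1ccc(-c2sc(C(=O)O)cc2-c2cc(OC)c(OC)c(OC)c2)cc1OCc1ccccc1` share one core and differ at a single aromatic carbon: benzyloxy in place of nitro on an aromatic carbon. In a functional assay on KB cells (Homo sapiens) for antiproliferative activity, read by MTT assay, with a stated time of 72 h (a higher number here means a weaker inhibitor, a lower number a stronger inhibitor), compound 1 gives 35900 nM. Compound 2 reaches only a limit of this assay, > 100000 nM. The step is an at least 2.7-fold higher number from compound 1 to compound 2 (0.44 log units; beyond the scatter), a reading that rests on (the limit of > 100000 nM in this assay, at which 1 of the 3 values shown sits). Compound 3 `COc1ccc(-c2ccsc2-c2cc(OC)c(OC)c(OC)c2)cc1[N+](=O)[O-]` carries a second core; how its core differs from that of compound 1 is not broken down here. In this assay compound 3 gives 21000 nM, a value within the scatter of compound 1. Compound 4 `COc1ccc(-c2ccsc2-c2cc(OC)c(OC)c(OC)c2)cc1OCc1ccccc1` carries the same change on this core: benzyloxy in place of nitro on an aromatic carbon. The surroundings of the place read the same in both pairs, so the change is called the same. Resting on an at least 2.7-fold higher number from compound 1 to compound 2 (0.44 log units; beyond the scatter), a comparable step is expected, estimated as a 3.8-fold higher number from compound 3 to compound 4 (0.58 log units; beyond the scatter). Compound 4 is therefore expected to give about 80000 nM, between 30000 nM and 200000 nM.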

Compound 4, half-maximal inhibitory concentration: > 100000 nM
Compound 4 was reported as a limit (the forecaster's own chance of this, stated with the estimate: 55%); middle value at least 1.2-fold (0.09 log units) away from the limit.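

On the second core the change again raises the number, with an at least 4.7-fold higher number from compound 3 to compound 4 (0.67 log units; beyond the scatter) in this assay. In both pairs shown, benzyloxy in place of nitro therefore gives a weaker compound, and the direction of the step carries over from the core of compound 1 to the core of compound 3: the same change on two cores in this assay, an at least 2.7-fold higher number (0.44 log units; beyond the scatter) from compound 1 to compound 2 and an at least 4.7-fold higher number (0.67 log units; beyond the scatter) from compound 3 to compound 4; the limit leaves it open whether they differ. The true size of neither step is shown, and a match in size cannot be claimed, since compound 2 and compound 4 both stand at a limit of the assay: the limit of > 100000 nM in this assay, at which 2 of the 4 values shown sit.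

The compounds shown leave open how an amine or a hydroxyl group at this place would compare with nitro and benzyloxy. They also leave open whether the same step holds on a core bearing an amide or a methyl ester in place of the carboxylic acid.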